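Notes on compound 4: dimethylamino in place of amino

The source may hold more compounds than are shown below. What is called first, only, known or untested is meant among the compounds shown, and "the series" means these compounds.

The series is followed in a physicochemical assay for solubility, read by HPLC, in phosphate buffer, measured as kinetic solubility, with a stated time of 24 h, at 20 degrees C, at pH 7.4, tested at 100 uM; on this read-out lower numbers stand for lower solubility and higher numbers for higher solubility. Compound 1 `CCc1nc(N)nc2c1c(-c1ccc3oc(N)nc3c1)nn2C(C)C` gives 62000 nM, compound 2 `CC(C)n1nc(-c2ccc3oc(N)nc3c2)c2c(Br)nc(N)nc21` gives 4000 nM, and compound 3 `CC(C)n1nc(-c2ccc3oc(N)nc3c2)c2c(=O)[nH]c(N)nc21` gives 9200 nM. Compound 3 stands second highest of the three numbers in this assay, with compound 2 nearest and compound 1 furthest, both gaps beyond the scatter. The one step shown, a 16-fold lower number from compound 1 to compound 2 (1.19 log units; beyond the scatter), concerns bromo in place of ethyl and does not touch the position changed here. Compound 4 `CC(C)n1nc(-c2ccc3oc(N)nc3c2)c2c(=O)[nH]c(N(C)C)nc21` differs from compound 3 by dimethylamino in place of amino on an aromatic carbon. No measured pair covers an amino group being exchanged, so nothing in the shown steps sets the size of this move; the expectation rests on compound 3 alone at 9200 nM. For compound 4 a modest downward step in this assay is expected, a 1.8-fold lower number from compound 3 to compound 4 (0.26 log units; within the scatter), near the edge of the scatter rather than clearly beyond it. The estimate for compound 4 in this assay is 5000 nM, within a range from 1500 nM to 16000 nM.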

Compound 4, solubility: 2000 nM
For compound 4 the middle estimate is 2.5-fold (0.40 log units) above the measured one, within the range that was stated.
By their numbers in this assay, from the lowest: compounds 4 and 2 (each within the scatter of the next); then compound 3; then compound 1.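

In this assay, among these compounds, the exchange of amino for dimethylamino on the aromatic carbon between two ring nitrogen atoms gives a 4.6-fold lower number from compound 3 to compound 4 (0.66 log units; beyond the scatter) and is the first step at this position, so the read-out does respond to a change there. The step replaces a group with 1 hydrogen-bond donor by one with 0 hydrogen-bond donors and adds 2 carbon atoms, and a single pair cannot tell these two differences apart. No measurement shown gives a reason for the step.

Methylamino at this position would help separate the two differences, while a cyclic amine such as morpholine would test larger groups there. From the compounds shown here alone, whether the step carries over to the ethyl or bromo compounds also remains open.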